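Shortening the Linker from Phenoxymethyl to Phenyl

The source may report more compounds than this note shows. Statements on the series, on what has been measured and on what is new or still open speak of the compounds shown alone.

The shared core carries a thioether chain ending in an aromatic ring. Compound 1 `O=C(O)Cn1c(SCCCOc2ccccc2)nc2ccccc21` gives 786 nM in an assay on HEK293 cells for displacement of a labelled ligand from prostaglandin D2 receptor 2 (Homo sapiens); on this read-out lower numbers stand for stronger inhibition and higher numbers for weaker inhibition. Compound 2 `O=C(O)Cn1c(SCCCCOc2ccccc2)nc2ccccc21` gives 1400 nM in this assay. For the measured compounds named here, the only step measured so far, a 1.8-fold higher number from compound 1 to compound 2 (0.25 log units; within the scatter), lengthens the chain by one carbon, and it lies within the scatter, so the two compounds cannot be ordered. Compound 3 `O=C(O)Cn1c(SCCCc2ccccc2)nc2ccccc21` is unmeasured; the change from compound 2 is phenyl in place of phenoxymethyl on a saturated chain carbon, three bonds along the chain from a sulfur. Going by the values given here, this removes the oxygen and two chain atoms, a larger change than the one measured step, which only added a carbon and showed no effect beyond the scatter. Nothing in the data shows what dropping the oxygen does, so a step close to no change beyond the scatter is expected, with wide uncertainty. Compound 3 is therefore estimated at 900 nM in this assay, with a range of 250 nM to 3200 nM, an expected step of a 1.6-fold lower number from compound 2 to compound 3 (0.19 log units; within the scatter).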

Compound 3, half-maximal inhibitory concentration: 475 nM
Compound 3: the middle estimate sits 1.9-fold (0.28 log units) above what was measured; the range from low to high includes it.
By their numbers in this assay, from the lowest: compounds 3, 1 and 2 (each within the scatter of the next, the first and the last beyond it).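

In this assay, for the compounds shown here, putting phenyl in place of phenoxymethyl at this place gives a 2.9-fold lower number from compound 2 to compound 3 (0.47 log units; beyond the scatter) and is the first step to clear the scatter, so the end of this chain can affect the read-out. The swap of phenyl for phenoxy gives a 1.7-fold lower number from compound 1 to compound 3 (0.22 log units; within the scatter) and cannot be told from noise, so compound 1 and compound 3 cannot be ordered, and the real gain holds only against compound 2. The data offer no explanation for this difference.

Still open, as far as these compounds go, is whether a chain ending in phenyl tolerates one more carbon, as a direct match to the longer chain of compound 2. Also open, from the compounds shown here alone, is how a fluorine or a methoxy group on the phenyl ring would shift the number.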